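From 1-phenylethyl to benzyl on the shared core

A few compounds are considered here, and "the series" means these few. Any claim that something is new, unique, unknown or untested is made for them only; others in the source may bear on it.

In a functional assay on MDA-MB-435 cells (Homo sapiens) for cytotoxicity, read by MTT assay, with a stated time of 72 h (a lower number here means a stronger inhibitor, a higher number a weaker inhibitor), compound 1 `NCCCNc1c(C(=O)NCc2ccc(F)cc2)nc(Br)c2cccnc12` gives 5000 nM. Compound 2 `O=C(NCc1ccc(F)cc1)c1nc(Br)c2cccnc2c1NCCO` gives only a limit, > 20000 nM. Compound 3 `C[C@H](Nc1c(C(=O)NCc2ccc(F)cc2)nc(Br)c2cccnc12)c1ccccc1` also gives only a limit, > 20000 nM, which is the limit of > 20000 nM in this assay, at which 2 of the 3 values shown sit.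

Compound 4 `O=C(NCc1ccc(F)cc1)c1nc(Br)c2cccnc2c1NCc1ccccc1` differs from compound 3 by hydrogen in place of methyl on a saturated chain carbon bound to an aromatic carbon and a nitrogen on an aromatic ring, so 1-phenylethyl becomes benzyl.

For the measured compounds named here, no measured step makes this exact change. The nearest are an at least 4.0-fold higher number from compound 1 to compound 3 (0.60 log units; beyond the scatter) and an at least 4.0-fold higher number from compound 1 to compound 2 (0.60 log units; beyond the scatter), while a step that the two limits leave unreadable from compound 2 to compound 3. Compound 4 lacks the 3-aminopropyl chain of compound 1, which gives 5000 nM, so no gain is expected. The expected step is an at least 1.1-fold lower number from compound 3 to compound 4 (0.04 log units; that floor lies within the scatter), with none beyond the scatter anticipated. The estimate for compound 4 is 18000 nM, ranging from 7000 nM to 30000 nM.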

Compound 4, half-maximal inhibitory concentration: > 20000 nM
Compound 4: no number, only a limit (the forecaster's own chance of this, stated with the estimate: 65%); middle value at least 1.1-fold (0.04 log units) away from the limit.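

Going from 1-phenylethyl to benzyl yields no readable change in this assay, and the steps from compound 3 and from compound 2 to compound 4 cannot be read, since both ends of each are limits: the limit of > 20000 nM in this assay, at which 3 of the 4 values shown sit.

Benzyl on the nitrogen on the aromatic ring gives an at least 4.0-fold higher number from compound 1 to compound 4 (0.60 log units; beyond the scatter). Losing the methyl therefore recovers nothing measurable, and of the four compounds only compound 1, with its 3-aminopropyl, gives a number, 5000 nM.

From the compounds shown here alone, how far the three compounds at the limit differ from one another stays open. So does what a longer amine chain, or a carboxylic acid at the chain end, would give on the shared core.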